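A methoxy group on the trifluoromethyl ketone

The source may hold more compounds than are shown below. What is called first, only, known or untested is meant among the compounds shown, and "the series" means these compounds.

Compound 1 `O=C(CCCCCCc1nc(-c2cccs2)no1)NO`: 320 nM
Compound 2 `Nc1ccccc1NC(=O)CCCCCCc1nc(-c2ccccc2)no1`: 730 nM
Compound 3 `O=C(CCCCCCc1nc(-c2ccccc2)no1)C(F)(F)F`: 410 nM

In a functional assay on U-937 cells (Homo sapiens) for antiproliferative activity, read by MTT assay, with a stated time of 72 h (on this read-out higher numbers stand for weaker inhibition and lower numbers for stronger inhibition), compound 3 gives 410 nM, which lies within the scatter of both compound 1 and compound 2. The next compound, compound 4 `COc1ccc(-c2noc(CCCCCCC(=O)C(F)(F)F)n2)cc1`, has not yet been measured. It keeps everything in compound 3 except one site, where phenyl becomes 4-methoxyphenyl: methoxy in place of hydrogen on an aromatic carbon. The methoxy thus takes the place of hydrogen on an aromatic carbon, para to a large group.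

The measured data offer little direct guidance on this change. Among the compounds with values here, the only step available, a 1.8-fold lower number from compound 2 to compound 3 (0.25 log units; within the scatter), places trifluoromethyl in place of (2-aminophenyl)amino on a carbonyl carbon, so it concerns a different site and stays within the scatter. Compound 1 differs from compound 3 in more than one place and cannot isolate the effect of any single change. Within the data shown here, no measured pair shows what a methoxy does at this site, so neither direction is favoured and the range must stay wide. In this assay the expected change is none beyond the scatter, with the estimate being a 1.0-fold higher number from compound 3 to compound 4 (0.01 log units; within the scatter). For compound 4 the estimated value is 420 nM, with an expected range from 170 nM to 1000 nM.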

Compound 4, half-maximal inhibitory concentration: 1170 nM
For compound 4 the middle estimate is 2.8-fold (0.44 log units) below the measured one, and the stated range ends below it.
By their numbers in this assay, from the lowest: compounds 1, 3, 2 and 4 (each within the scatter of the next, the first and the last beyond it).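

In this assay the step of a 2.9-fold higher number from compound 3 to compound 4 (0.46 log units; beyond the scatter) is a modest one, but it is the first single change shown that lies beyond the scatter, and the first made on the aromatic ring rather than at the carbonyl carbon. It shows that this ring position is not indifferent to substitution: with everything else held as in compound 3, methoxy in place of hydrogen on an aromatic carbon, para to a large group, goes with weaker inhibition of cell growth. Nothing available bears on why the methoxy has this effect, so the result stands as an observation on this one pair.

The compounds shown leave open whether a methyl, a chlorine or a hydroxyl on the same carbon would give a similar step, so the result cannot yet be assigned to methoxy in particular or to any replacement of that hydrogen. They also leave open whether the same change would carry over to the (2-aminophenyl)amino carbonyl of compound 2, since this single pair rests on the trifluoromethyl ketone alone.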